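A few compounds are considered here, and "the series" means these few. Any claim that something is new, unique, unknown or untested is made for them only; others in the source may bear on it.

Working notes on the series. Going by the values given here, compound 1 `CN1CCN(c2ccc(Nc3ncc4nc(Nc5ccc(F)cc5)n(-c5cccc(NC(=O)CO)c5)c4n3)cc2)CC1` gives 1510 nM in a functional assay on A549 cells (Homo sapiens) for antiproliferative activity, read by MTT assay, with a stated time of 72 h (on this read-out lower numbers stand for stronger inhibition and higher numbers for weaker inhibition), the only number available. Compound 2 `CC(=O)Nc1cccc(-n2c(Nc3ccc(F)cc3)nc3cnc(Nc4ccc(N5CCN(C)CC5)cc4)nc32)c1` gives "not determined" (no result reported) in this assay, so it stands nowhere on the numbers shown, and no step from compound 1 to compound 2 can be stated. Compound 3 `CN1CCN(c2ccc(Nc3ncc4nc(Nc5ccc(F)cc5)n([C@H]5CCN(S(=O)(=O)C6CC6)C5)c4n3)cc2)CC1` differs from compound 2 by 1-(cyclopropylsulfonyl)pyrrolidin-3-yl in place of 3-acetamidophenyl on an aromatic nitrogen. Among the compounds with values here, no measured step bears on this change, so no direction beyond the scatter is expected in this assay, only uncertainty of size. Compound 3 is estimated at 1500 nM, between 300 nM and 7000 nM.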

Compound 3, half-maximal inhibitory concentration: 150 nM
The estimate for compound 3 lay 10-fold (1.00 log units) above the measured number, outside the stated range (below it).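

On this position, this assay responds to the group on the aromatic nitrogen: 1-(cyclopropylsulfonyl)pyrrolidin-3-yl in place of 3-(((hydroxymethyl)carbonyl)amino)phenyl gives a 10-fold lower number from compound 1 to compound 3 (1.00 log units; beyond the scatter), so a phenyl ring is not required there. The change from the 3-acetamidophenyl of compound 2 cannot be read, as compound 2 has no number. Nothing measured here explains the step. As far as these compounds go, it remains open whether the step follows the cyclopropylsulfonyl group, the pyrrolidine ring or the defined stereocentre. A free pyrrolidine amine, a methylsulfonyl group or the opposite stereoisomer would separate these.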